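A few compounds are considered here, and "the series" means these few. Any claim that something is new, unique, unknown or untested is made for them only; others in the source may bear on it.

In an assay on HEK293 cells for displacement of a labelled ligand from growth hormone secretagogue receptor type 1 (Homo sapiens), with a stated time of 60 min (a lower number here means a stronger inhibitor, a higher number a weaker inhibitor), compound 2 `CCc1ccc(Cl)c(C(=O)NC(=O)Nc2nc3ccc(S(=O)(=O)CCCN4CCN(C)CC4)cc3s2)c1` gives 0.078 nM, the lowest of three numbers. Compound 1 `CN1CCC(S(=O)(=O)c2ccc3nc(NC(=O)NC(=O)c4cc(N5CCCC5)ccc4Cl)sc3c2)CC1` gives 0.92 nM, a higher number beyond the usual scatter, and compound 3 `CN(C)CCCS(=O)(=O)c1ccc2nc(NC(=O)NC(=O)c3ccccc3Cl)sc2c1` gives 8.7 nM, higher still. Compound 4 `CN1CCN(CCCS(=O)(=O)c2ccc3nc(NC(=O)NC(=O)c4cc(-n5cccn5)ccc4Cl)sc3c2)CC1` has not yet been measured in this assay; it differs from compound 2 in one place, (1H-pyrazol-1-yl in place of ethyl on an aromatic carbon). For the measured compounds named here, no measured pair here shows this exact change, so its effect can only be guessed. Compound 1, which carries a ring at the same place but a different tail, shows with 0.92 nM that a ring there is tolerated. The expected step of a 3.8-fold higher number from compound 2 to compound 4 (0.59 log units; beyond the scatter) is a modest weakening, likely a little beyond the scatter. Compound 4 is therefore estimated at 0.3 nM, with a range from 0.08 nM to 1.2 nM.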

Compound 4, half-maximal inhibitory concentration: 0.67 nM
Beside the measured number, compound 4's estimate is 2.2-fold (0.35 log units) below it, and the stated range covers the measured number.
By their numbers in this assay, from the lowest: compound 2; then compounds 4 and 1 (each within the scatter of the next); then compound 3.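

In this assay, for the compounds shown here, the change on the aromatic carbon para to the chloro group gives an 8.6-fold higher number from compound 2 to compound 4 (0.93 log units; beyond the scatter), the first reading at this position with the rest of the molecule held constant. The 1H-pyrazol-1-yl ring is tolerated there, but ethyl gives the lower number. Nothing available explains this difference.

As far as these compounds go, it remains open how a methoxy group or a longer chain such as propyl would fare at this position. It is also unclear whether the same step would appear with a different tail on the shared core.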